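Replacing the 1-carboxyethyl group of compound 2

The compounds below may be only part of what the source reports. "The series", "measured", "known", "first", "only" and "open" are said of these compounds alone.

Compound 1 `COC(=O)C(Nc1cc(CS(=O)(=O)/C=C/c2c(OC)cc(OC)cc2OC)ccc1OC)c1ccc(Cl)cc1`: 200 nM
Compound 2 `COc1cc(OC)c(/C=C/S(=O)(=O)Cc2ccc(OC)c(N[C@@H](C)C(=O)O)c2)c(OC)c1`: 15 nM

Within the data shown here, in a functional assay on K562 cells (Homo sapiens) for cytotoxicity, read by trypan blue exclusion, with a stated time of 96 h (on this read-out lower numbers stand for stronger inhibition and higher numbers for weaker inhibition), compound 2 gives 15 nM, the lower of the two numbers so far. Compound 3 `COc1ccc(C(Nc2cc(CS(=O)(=O)/C=C/c3c(OC)cc(OC)cc3OC)ccc2OC)C(=O)O)cc1` has not yet been measured. It differs from compound 2 by carboxy(4-methoxyphenyl)methyl in place of 1-carboxyethyl on a nitrogen on an aromatic ring. Among the measured compounds shown here, one measured step bears on this change, a 13-fold lower number from compound 1 to compound 2 (1.12 log units; beyond the scatter), and it is large. That step exchanged (4-chlorophenyl)(methoxycarbonyl)methyl for 1-carboxyethyl, so it does not separate the loss of the ring from the change to the carboxy group. Compound 3 keeps a carboxy group but regains a ring, which suggests only part of that step returns. The expected step, upward and smaller than the measured one, is a 3.3-fold higher number from compound 2 to compound 3 (0.52 log units; beyond the scatter). In this assay the estimated value for compound 3 is 50 nM, with an expected range of 12 nM to 200 nM.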

Compound 3, half-maximal inhibitory concentration: 15 nM
For compound 3 the middle estimate is 3.3-fold (0.52 log units) above the measured one, and the stated range covers the measured number.
By their numbers in this assay, from the lowest: compounds 2 and 3 (each within the scatter of the next); then compound 1.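

In this assay, carboxy(4-methoxyphenyl)methyl, with its six-membered aromatic ring and 12 heavy atoms, replaces 1-carboxyethyl on the nitrogen with no change at the digits printed from compound 2 to compound 3 (within the scatter), so among these compounds a ring on this group is compatible with a low number when the carboxy group is present. With a ring in both groups, the comparison still gives a 13-fold lower number from compound 1 to compound 3 (1.12 log units; beyond the scatter), which shows that the ring lost in the earlier step does not by itself mark the difference from compound 1. No evidence at hand accounts for this result.

The compounds shown leave open whether the remaining gap belongs to the carboxy group or to the 4-chlorophenyl ring. They also leave open how this position would respond to a primary amide or a sulfonic acid in place of the carboxy group.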